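Replacing furan with hydroxyphenyl on the hydrazone carbon

A few compounds are considered here, and "the series" means these few. Any claim that something is new, unique, unknown or untested is made for them only; others in the source may bear on it.

Compounds with measured values:
compound 1 `O=C(CSc1nnnn1-c1cccc2ccccc12)N/N=C/c1ccco1` — > 330000 nM
compound 2 `O=C(CSc1nnnn1-c1cccc2ccccc12)N/N=C/c1ccccc1Cl` — 69700 nM
compound 3 `COc1ccc(/C=N/NC(=O)CSc2nnnn2-c2cccc3ccccc23)cc1OC` — 191000 nM

In an ADME assay on MT4 cells (Homo sapiens) for cytotoxicity, read by MTT assay (on this read-out lower numbers stand for higher toxicity in this test and higher numbers for lower toxicity in this test), compound 1 gives > 330000 nM, which is a limit of the assay and not a number. Compound 2 gives 69700 nM, and compound 3 gives 191000 nM. The change that leads from compound 1 to compound 4 `O=C(CSc1nnnn1-c1cccc2ccccc12)N/N=C/c1ccccc1O` is this: 2-hydroxyphenyl in place of furan-2-yl on a carbon with a double bond to nitrogen. Two measured steps start from compound 1 and bear on it. Exchanging the furan for an aromatic six-membered ring gave an at least 4.7-fold lower number from compound 1 to compound 2 (0.67 log units; beyond the scatter) and an at least 1.7-fold lower number from compound 1 to compound 3 (0.23 log units; that floor lies within the scatter); between those two rings, a 2.7-fold higher number from compound 2 to compound 3 (0.44 log units; beyond the scatter). As far as these compounds go, since compound 1 sits at the limit of > 330000 nM in this assay, at which 1 of the 3 values shown sits, the true size of both steps from it is unknown. A lower number, that is more toxicity in this assay, appears the likelier direction for compound 4, but its size may stay modest. Compound 4 is therefore expected to give about 150000 nM, within 50000 nM to 330000 nM. The estimated step of an at least 2.2-fold lower number from compound 1 to compound 4 (0.34 log units; beyond the scatter) expresses this expectation.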

Compound 4, half-maximal cytotoxic concentration: 4850 nM
For compound 4 the middle estimate is 31-fold (1.49 log units) above the measured one; the measured number lies below the stated range.
By their numbers in this assay, from the lowest: compound 4; then compound 2; then compound 3. At a limit, above all of these: compound 1.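

In this assay, the earlier exchanges on the carbon with a double bond to nitrogen produced steps no larger than modest where both ends were measured, whereas 2-hydroxyphenyl produces a 39-fold lower number from compound 3 to compound 4 (1.60 log units; beyond the scatter) and an at least 68-fold lower number from compound 1 to compound 4 (1.83 log units; beyond the scatter). Exchanging only chloro for hydroxy on an aromatic carbon gives a 14-fold lower number from compound 2 to compound 4 (1.16 log units; beyond the scatter), so toxicity in this test depends strongly on the group carried by the six-membered ring, and not merely on that ring being present. The value of compound 1 is a limit of the assay, so its step gives only a floor: the limit of > 330000 nM in this assay, at which 1 of the 4 values shown sits.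

As far as these compounds go, it remains open whether the hydroxy group must sit exactly as in 2-hydroxyphenyl, as a 4-hydroxyphenyl ring would test. From the compounds shown here alone, it is equally open whether a 2-methoxyphenyl or 2-aminophenyl ring would give a similarly low number.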